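A Carboxy Group Enters the Aryl Ketone Ring

This account rests on a few compounds, and the source may have more. Where it says the series, first, only, none or still open, it means among the compounds named here.

Compound 1 `O=C(/C=C/c1ccc2c(c1)B(O)OC2)c1ccccc1` is the parent of a small set tested in a functional assay on MDA-MB-231 cells (Homo sapiens) for cytotoxicity, read by MTT assay, with a stated time of 48 h (on this read-out higher numbers stand for weaker inhibition and lower numbers for stronger inhibition), where compound 1 gives 2300 nM, the lowest of the three numbers shown. Compound 2 `COc1ccccc1C(=O)/C=C/c1ccc2c(c1)B(O)OC2` carries a methoxy on an aromatic carbon and gives 3100 nM; compound 3 `COCOc1ccccc1C(=O)/C=C/c1ccc2c(c1)B(O)OC2` carries a methoxymethoxy on that carbon and gives 10200 nM. The step of a 1.3-fold higher number from compound 1 to compound 2 (0.13 log units; within the scatter) stays within the scatter, whereas a 4.4-fold higher number from compound 1 to compound 3 (0.65 log units; beyond the scatter) and a 3.3-fold higher number from compound 2 to compound 3 (0.52 log units; beyond the scatter) are modest losses. Compound 4 `O=C(O)c1ccc(C(=O)/C=C/c2ccc3c(c2)B(O)OC3)cc1` has not yet been measured; it differs from compound 1 by carboxy in place of hydrogen on an aromatic carbon, on an aromatic carbon of a six-membered aromatic ring of carbon only, para to a large group. Both measured steps bear on it, since each also adds a group to an aromatic carbon of compound 1, and neither gave a lower number beyond the scatter. For compound 4 a modest step toward a higher number is therefore expected: a 2.2-fold higher number from compound 1 to compound 4 (0.34 log units; beyond the scatter). Compound 4 is estimated at 5000 nM, within 2000 nM to 15000 nM.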

Compound 4, half-maximal inhibitory concentration: > 100000 nM
Compound 4: only a limit was reported; the forecaster's own chance of this, stated with the estimate: 5%; middle value at least 20-fold (1.30 log units) away from the limit.
By their numbers in this assay, from the lowest: compounds 1 and 2 (each within the scatter of the next); then compound 3. At a limit, above all of these: compound 4.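

In this assay, going by these compounds alone, carboxy in place of hydrogen on this aromatic carbon, para to a large group, gives the only large step in the set: an at least 43-fold higher number from compound 1 to compound 4 (1.63 log units; beyond the scatter). Within the data shown here, compound 4 sits at a limit, not at a measured number: the limit of > 100000 nM in this assay, at which 1 of the 4 values shown sits. The earlier compounds gave no sign of a loss this size, so a group added to an aromatic carbon of compound 1 cannot be assumed to be as mild as the methoxy of compound 2 or the methoxymethoxy of compound 3.

Carboxy appears only at this place and those two groups only at another aromatic carbon, so the compounds shown do not separate the effect of the group from that of its place. As far as these compounds go, what a methyl ester or an amine would give on this same carbon stays open, as does carboxy on the carbon that carries methoxy in compound 2.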